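The source may report more compounds than this note shows. Statements on the series, on what has been measured and on what is new or still open speak of the compounds shown alone.

Three compounds share one core and differ only in the aromatic group attached to it. Compound 1 `COc1ccc(-c2cc(N)c(C(=O)c3cc(OC)c(OC)c(OC)c3)s2)cc1OC` carries a 3,4-dimethoxyphenyl group and gives 72 nM in a functional assay on FM3A cells (Mus musculus) for antiproliferative activity; on this read-out lower numbers stand for stronger inhibition and higher numbers for weaker inhibition. Compound 2 `COc1cc(C(=O)c2sc(-c3ccc(I)cc3)cc2N)cc(OC)c1OC` carries a 4-iodophenyl group, and in this assay compound 2 gives 420 nM, the highest of the three numbers, which here means the weakest inhibition. Compound 3 `COc1cc(C(=O)c2sc(-c3cccs3)cc2N)cc(OC)c1OC` carries a thiophen-2-yl group, and in this assay compound 3 gives 1.7 nM.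

The recorded steps run a 5.8-fold higher number from compound 1 to compound 2 (0.77 log units; beyond the scatter), a 42-fold lower number from compound 1 to compound 3 (1.63 log units; beyond the scatter) and a 250-fold lower number from compound 2 to compound 3 (2.39 log units; beyond the scatter).

Compound 4 `COc1cc(C(=O)c2sc(-c3ccc(C(F)(F)F)cc3)cc2N)cc(OC)c1OC` is not yet measured. It differs from compound 2 in one place: trifluoromethyl in place of iodo on an aromatic carbon. Going by the values given here, of the measured steps, only the step from compound 1 to compound 2 concerns a change on the six-membered carbon ring while keeping that ring in place, and it was modest in size. The two steps to compound 3 exchange the whole ring and therefore say little about swapping one group on it. The ring itself stays, so a step of modest size at most is expected, with the direction uncertain and possibly within the scatter.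

Compound 4 is therefore estimated at 300 nM in this assay, in a range from 100 nM to 900 nM, which would mean a 1.4-fold lower number from compound 2 to compound 4 (0.15 log units; within the scatter).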

Compound 4, half-maximal inhibitory concentration: 540 nM
The estimate for compound 4 lay 1.8-fold (0.26 log units) below the measured number; low and high end bracket the measured number.
By their numbers in this assay, from the lowest: compound 3; then compound 1; then compounds 2 and 4 (each within the scatter of the next).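

In this assay, putting trifluoromethyl in place of iodo, para to a large group, gives a 1.3-fold higher number from compound 2 to compound 4 (0.11 log units; within the scatter) and so does not separate these two groups on this read-out, even though 1 heavy atom leaves and 4 heavy atoms enter. The remaining steps, a 7.5-fold higher number from compound 1 to compound 4 (0.88 log units; beyond the scatter) and a 320-fold higher number from compound 3 to compound 4 (2.50 log units; beyond the scatter), put compound 4 on the same side of compound 1 and of compound 3 as compound 2, so among these compounds the two phenyl rings bearing a single group at this place both give higher numbers than the 3,4-dimethoxyphenyl and thiophen-2-yl compounds. Nothing measured here explains why iodo and trifluoromethyl read alike or why the thiophen-2-yl compound stands so far from them.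

Going by these compounds, what an amine, a carboxylic acid or a longer chain such as butyl would do at this same place on the phenyl ring stays open, so the two matching values cannot be taken as a rule for all groups there. On these data alone, it is also open whether a methyl or a methoxy group alone at this place would move the number towards that of compound 1 or stay with compounds 2 and 4.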